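The compounds below may be only part of what the source reports. "The series", "measured", "known", "first", "only" and "open" are said of these compounds alone.

For the measured compounds named here, compound 1 `COc1ccc(C(=O)O)cc1OCCCCOc1ccc(C(=O)CC2CCCC2)c(O)c1C` stands highest of the two values so far in an assay on HEK293 cells for positive allosteric modulation of metabotropic glutamate receptor 2 (Rattus norvegicus), read by thallium flux, with a stated time of 2.5 min; a higher number here means a larger maximal response, a lower number a smaller maximal response; compound 1 gives 91.8%, and its nearest measured neighbour, compound 2 `COc1ccc(C(=O)O)cc1OCCCCOc1ccc(C(=O)C(C)C)c(O)c1C`, gives 66.6%. Going by the values given here, the only measured step, a number 25.2 percentage points lower from compound 1 to compound 2 (beyond the scatter), puts isopropyl in place of cyclopentylmethyl on a carbonyl carbon and leaves the rest of the shared core untouched. Compound 3 `Cc1cc(C(=O)O)ccc1OCCCCOc1ccc(C(=O)CC2CCCC2)c(O)c1C` differs from compound 1 elsewhere: 4-carboxy-2-methylphenyl in place of 5-carboxy-2-methoxyphenyl on an oxygen on a saturated carbon. Among the compounds with values here, no measured step touches that part of the molecule, so nothing measured bears directly on this change; the one step recorded sits on the carbonyl carbon and is of modest size. The change is therefore expected to stay within or close to the scatter in this assay, with its direction uncertain. Compound 3 is estimated at 85%, within 60% to 100%, meaning an expected step of a number 6.8 percentage points lower from compound 1 to compound 3 (within the scatter).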

Compound 3, largest response reached (reported as percent of maximum), in percent of the reference or control that the assay uses: 84.6%
The estimate for compound 3 lay 0.4 percentage points above the measured number; measured number inside the range.
By their numbers in this assay, from the lowest: compound 2; then compounds 3 and 1 (each within the scatter of the next).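

For the compounds shown here, at the place on an oxygen on a saturated carbon, 4-carboxy-2-methylphenyl in place of 5-carboxy-2-methoxyphenyl gives a number 7.2 percentage points lower from compound 1 to compound 3 (within the scatter) in this assay, the first measured step at this end of the molecule. Going by these compounds alone, the entering group has one hydrogen-bond acceptor where the leaving group has two, and the maximal response stays within the scatter of compound 1, so this end accepts this exchange, while a number 25.2 percentage points lower from compound 1 to compound 2 (beyond the scatter) on the carbonyl carbon remains the only step beyond the scatter. Nothing available explains this result.

The exchange alters the aryl substituent and the placement of the carboxy group together, so the contribution of each remains unresolved. Also open, as far as these compounds go, is whether a tetrazole or a primary amide could stand in for the carboxylic acid, and whether a longer chain on the oxygen would hold the response.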